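A few compounds are considered here, and "the series" means these few. Any claim that something is new, unique, unknown or untested is made for them only; others in the source may bear on it.

Measured so far:
Compound 1, `Cc1ccccc1-c1cnccc1C(=O)N(C)Cc1cc(C(F)(F)F)cc(C(F)(F)F)c1` — 4.6 nM
Compound 2, `Cc1ccccc1-c1cnccc1N(C)C(=O)C(C)(C)c1cc(C(F)(F)F)cc(C(F)(F)F)c1` — 3.3 nM

Of the compounds shown here, two have been measured in an assay on CHO cells for displacement of a labelled ligand from Substance-P receptor (Homo sapiens); on this read-out lower numbers stand for stronger inhibition and higher numbers for weaker inhibition. Compound 2 shows the lower of the two numbers, but its gap to compound 1 lies within the usual scatter, so the two cannot be placed in any order on this evidence.

Compound 3, `Cc1ccccc1-c1cnc(N2CCN(C)CC2)cc1N(C)C(=O)C(C)(C)c1cc(C(F)(F)F)cc(C(F)(F)F)c1`, has not yet been measured. It differs from compound 2 in one place: 4-methylpiperazin-1-yl in place of hydrogen on an aromatic carbon. Going by the values given here, no pair of measured compounds with a comparable change is available, so the size of this step is not anchored by any measured step.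

In the absence of such an anchor, the expected step from compound 2 to compound 3 is a 1.7-fold lower number from compound 2 to compound 3 (0.22 log units; within the scatter), that is, no change beyond the scatter, with a slight lean toward a lower number. Compound 3 is therefore estimated at 2 nM, with a range from 0.5 nM to 8 nM.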

Compound 3, inhibition constant: 1.7 nM
Beside the measured number, compound 3's estimate is 1.2-fold (0.07 log units) above it; the measured number falls inside the stated range.
By their numbers in this assay, from the lowest: compounds 3, 2 and 1 (each within the scatter of the next, the first and the last beyond it).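

Going by these compounds alone, the step of a 1.9-fold lower number from compound 2 to compound 3 (0.29 log units; within the scatter) in this assay is the first reading for this position, an aromatic carbon next to the ring nitrogen and para to the 2-methylphenyl group. Hydrogen there can give way to 4-methylpiperazin-1-yl, a six-membered non-aromatic ring of 7 heavy atoms, while the two numbers remain within the scatter of each other. No evidence is available to explain this result.

The compounds shown leave open whether a piperazine without its methyl group, a morpholine ring or a small open-chain amine such as dimethylamino would give a number in the same range at this position. They also leave open whether 4-methylpiperazin-1-yl would be accommodated in the same way on the core of compound 1, with its reversed amide.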